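The source may hold more compounds than are shown below. What is called first, only, known or untested is meant among the compounds shown, and "the series" means these compounds.

Three compounds share one core and differ only in the group carried on it. Compound 1 `c1ccc(-c2cn3ccnc3c(-c3ccc4ncn(C5CCCCC5)c4c3)n2)cc1` carries a phenyl; in a functional assay on EKVX cells (Homo sapiens) for inhibition, read by sulforhodamine B assay, with a stated time of 48 h, tested at 10 uM (on this read-out higher numbers stand for more inhibition at the one concentration tested (going by the name of the read-out) and lower numbers for less inhibition), compound 1 gives 24.2%. Compound 2 `c1ccc2c(-c3cn4ccnc4c(-c4ccc5ncn(C6CCCCC6)c5c4)n3)cccc2c1` carries a naphthalen-1-yl, and in this assay compound 2 gives 13.3%. Compound 3 `Brc1ccc(-c2cn3ccnc3c(-c3ccc4ncn(C5CCCCC5)c4c3)n2)cc1` carries a 4-bromophenyl, and in this assay compound 3 gives 16.2%. That places compound 3 second highest of the three numbers, with compound 2 nearest and compound 1 furthest, both gaps within the scatter.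

Compound 4 `Fc1ccccc1-c1cn2ccnc2c(-c2ccc3ncn(C4CCCCC4)c3c2)n1` is not yet measured. It differs from compound 3 in this way: 2-fluorophenyl in place of 4-bromophenyl on an aromatic carbon. For the measured compounds named here, two measured steps bear on a swap of the group at this place. The step of a number 8 percentage points lower from compound 1 to compound 3 (within the scatter) shows that adding a bromo to the phenyl changed little. The step of a number 2.9 percentage points higher from compound 2 to compound 3 (within the scatter) shows that exchanging a whole aromatic group also changed little. Since the change to compound 4 is of the same kind, the step expected for compound 4 is a number 3.8 percentage points higher from compound 3 to compound 4 (within the scatter). For compound 4 in this assay a value of 20% is estimated, in the range 8% to 32%.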

Compound 4, a percentage reported as inhibition, at one concentration (the size of the read-out at that concentration, not a potency): 16%
Compound 4: the middle estimate sits 4 percentage points above what was measured; the measured number falls inside the stated range.
By their numbers in this assay, from the lowest: compounds 2, 4, 3 and 1 (each within the scatter of the next, the first and the last beyond it).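

In this assay, replacing the 4-bromophenyl with a 2-fluorophenyl gives a number 0.2 percentage points lower from compound 3 to compound 4 (within the scatter) and so changes the halogen and where it sits on the phenyl at once, yet the two numbers cannot be told apart. The other new comparisons, a number 2.7 percentage points higher from compound 2 to compound 4 (within the scatter) and a number 8.2 percentage points lower from compound 1 to compound 4 (within the scatter) as well, also stay inside the usual scatter, so compound 4 cannot be separated from any of the three earlier compounds. No available evidence explains why these numbers lie so close together.

Going by these compounds, it remains open whether a group of a different kind at this place, such as an amine, a carboxylic acid or a longer chain, would move the number beyond the scatter. The cyclohexyl group is also the same in all four compounds, so its contribution cannot be judged from them.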